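Changing the Aryl Group of Compound 2

A few compounds are considered here, and "the series" means these few. Any claim that something is new, unique, unknown or untested is made for them only; others in the source may bear on it.

In a functional assay on NCI-H1299 cells (Homo sapiens) for inhibition, read by CCK-8 assay, with a stated time of 72 h, tested at 1 uM (on this read-out higher numbers stand for more inhibition of growth at the one concentration tested and lower numbers for less inhibition of growth), compound 2 `CN(C)C(=O)c1cc2cnc(Nc3ccc(NC(=O)C4(C(=O)Nc5ccc(Cl)c(C(F)(F)F)c5)CC4)cc3)nc2n1C1CCCC1` gives 39.5%. Compound 1 `CN(C)C(=O)c1cc2cnc(Nc3ccc(NC(=O)C4(C(=O)Nc5cccc(Cl)c5)CC4)cc3)nc2n1C1CCCC1` gives 47.9%, so these two numbers lie within the scatter of each other. Compound 3 `CN(C)C(=O)c1cc2cnc(Nc3ccc(NC(=O)C4(C(=O)Nc5ccc(O)cc5)CC4)cc3)nc2n1C1CCCC1` changes one place of compound 2: 4-hydroxyphenyl in place of 4-chloro-3-(trifluoromethyl)phenyl on an amide-type nitrogen. For the measured compounds named here, the only measured step at this place, a number 8.4 percentage points lower from compound 1 to compound 2 (within the scatter), stayed within the scatter, yet it involved no 4-hydroxyphenyl, so the evidence is thin and suggests no direction. Expected here, then, is no shift beyond the scatter, with an estimated a number 0.5 percentage points higher from compound 2 to compound 3 (within the scatter). For compound 3 the estimate is 40%, with an expected range of 22% to 58%.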

Compound 3, percent growth inhibition at one concentration: 87.4%
Beside the measured number, compound 3's estimate is 47.4 percentage points below it; the whole stated range lies below it.
By their numbers in this assay, from the lowest: compounds 2 and 1 (each within the scatter of the next); then compound 3.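

In this assay, a single swap on the amide-type nitrogen gives a number 47.9 percentage points higher from compound 2 to compound 3 (beyond the scatter) and also a number 39.5 percentage points higher from compound 1 to compound 3 (beyond the scatter) on the same nitrogen, so this position can move growth inhibition well beyond the scatter. The earlier change between two chlorine-bearing aryl groups did not reveal this. Unlike 4-chloro-3-(trifluoromethyl)phenyl, the entering 4-hydroxyphenyl carries a hydrogen-bond donor and acceptor, but that difference is only counted here and is not shown to produce the rise. From the compounds shown here alone, whether a 4-methoxyphenyl or 4-aminophenyl group would give a similar number remains open. No measurement shown here explains the rise.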